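The source may report more compounds than this note shows. Statements on the series, on what has been measured and on what is new or still open speak of the compounds shown alone.

Measured so far:
compound 1, `CCCc1onc(-c2c(Cl)cccc2Cl)c1C(=O)Nc1ccc(N(CC)CC)cc1`, 131 nM
compound 2, `CCN(CC)c1ccc(NC(=O)c2c(-c3c(Cl)cccc3Cl)noc2C(C)C)cc1`, 150 nM

Going by the values given here, in an in vitro assay on CHO-K cells with growth hormone secretagogue receptor type 1 (Homo sapiens) as the target (a lower number here means a stronger inhibitor, a higher number a weaker inhibitor), compound 2 gives the higher of the two numbers, yet the only step between them, a 1.1-fold higher number from compound 1 to compound 2 (0.06 log units; within the scatter), lies within the scatter, so the two compounds cannot be placed in any order. Compound 3, `CCN(CC)c1ccc(NC(=O)c2c(-c3c(Cl)cccc3Cl)noc2CCOC)cc1`, differs from compound 2 by 2-methoxyethyl in place of isopropyl on an aromatic carbon. Among the compounds with values here, the single measured step that bears on this change is a 1.1-fold higher number from compound 1 to compound 2 (0.06 log units; within the scatter), which exchanged one alkyl group for another at the same aromatic carbon and did not move the number beyond the scatter. Within the data shown here, the change to compound 3 brings an oxygen-bearing chain to that position, for which no measured step exists. The step from compound 2 to compound 3 is therefore expected to be small, a 1.1-fold higher number from compound 2 to compound 3 (0.03 log units; within the scatter), and compound 3 is estimated at 160 nM, within a range from 70 nM to 400 nM.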

Compound 3, half-maximal inhibitory concentration: 110 nM
For compound 3 the middle estimate is 1.5-fold (0.16 log units) above the measured one, and the stated range covers the measured number.
By their numbers in this assay, from the lowest: compounds 3, 1 and 2 (each within the scatter of the next).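

In this assay, going by these compounds alone, the earlier step compared only one alkyl group with another, whereas 2-methoxyethyl brings an oxygen-bearing chain to this aromatic carbon next to the ring oxygen, and replacing isopropyl with it gives a step that stays within the scatter (a 1.4-fold lower number from compound 2 to compound 3 (0.13 log units; within the scatter)). Seen as methoxy in place of methyl on the saturated chain, the change also stays within the scatter (a 1.2-fold lower number from compound 1 to compound 3 (0.08 log units; within the scatter)), so among compounds 1, 2 and 3 neither branching nor the added oxygen separates the numbers. No measured evidence accounts for this result.

As far as these compounds go, whether a carboxylic acid, an amine such as a 2-aminoethyl chain, or a longer chain at this carbon would move the number beyond the scatter remains open. So does the effect of a ring at this position, such as cyclopropyl or phenyl.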